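The source may report more compounds than this note shows. Statements on the series, on what has been measured and on what is new or still open speak of the compounds shown alone.

Working notes on the series.

For the measured compounds named here, compound 1 `Fc1cccc(NC(=S)N/N=C/c2ccc3ccccc3n2)c1` is the only member of the set for which a functional assay on HL-60 cells (Homo sapiens) for antiproliferative activity, read by sulforhodamine B assay, with a stated time of 72 h (a lower number here means a stronger inhibitor, a higher number a weaker inhibitor), returns a number, 43800 nM, and even that is a weak value. Compound 2 `NC(=S)N/N=C/c1cc2ccccc2s1` returns in this assay only a limit, > 100000 nM. Compound 3 `NC(=S)N/N=C/c1nc2ccccc2s1` likewise returns in this assay a limit, > 100000 nM. Two of the three results therefore rest at the limit of > 100000 nM in this assay, at which 2 of the 3 values shown sit, and compound 1 stands alone as the single quantified point. Going by the values given here, no two measured compounds differ in a single place, so no measured step exists to calibrate any change.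

Compound 4 `S=C(N/N=C/c1ccc2ccccc2n1)Nc1ccccc1` is the next compound to be run. Set against compound 1 the change is hydrogen in place of fluoro on an aromatic carbon. The measured compounds offer nothing that bears on this change directly; the fluoro is removed and a hydrogen takes its place, with no heavy atom entering. The expectation in this assay is a step that stays within the scatter, or at most a modest weakening, with a real possibility that only a limit rather than a number is reported. Compound 4 is thus expected to give 55000 nM, with a range from 20000 nM to 130000 nM. The step expected here is a 1.3-fold higher number from compound 1 to compound 4 (0.10 log units; within the scatter).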

Compound 4, half-maximal inhibitory concentration: 9130 nM
Estimate against measurement, compound 4: 6.0-fold (0.78 log units) above; the whole stated range lies above it.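

For the compounds shown here, the step of a 4.8-fold lower number from compound 1 to compound 4 (0.68 log units; beyond the scatter) in this assay is the first measured step, and it shows that this place on the aromatic ring is not silent: hydrogen in place of fluoro moves the read-out beyond the scatter. Its direction is also now fixed for this one pair, since the 3-fluorophenyl to phenyl change gives the lower number and so the stronger inhibitor, although a single pair supports no general rule about fluoro and gives no cause for the step. Compound 1 and compound 4 are now the only two quantified points, and the rest of the set still gives limits rather than numbers: the limit of > 100000 nM in this assay, at which 2 of the 4 values shown sit.

Open, going by these compounds, is whether the same place tolerates anything other than hydrogen and fluoro, such as a chloro, a methyl, a methoxy or an amine, and whether fluoro elsewhere on the same ring would give a similar step. Going by these compounds alone, compound 2 and compound 3 differ from compound 4 in more than one place, so no steps to them can be read, and what the core itself contributes remains unresolved.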